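The source may report more compounds than this note shows. Statements on the series, on what has been measured and on what is new or still open speak of the compounds shown alone.

Compound 2 `Cc1ccccc1Nc1nc(SCc2ccc(C(F)(F)F)cc2)nc2ccccc12` and compound 3 `Cc1ccc(Nc2nc(SCc3ccc(C(F)(F)F)cc3)nc3ccccc23)cc1` share one core and differ only in that (4-methylphenyl in place of 2-methylphenyl on a nitrogen on an aromatic ring). In a functional assay on HGC-27 cells (Homo sapiens) for cytotoxicity, read by MTT assay, with a stated time of 72 h (on this read-out lower numbers stand for stronger inhibition and higher numbers for weaker inhibition), compound 2 gives 27500 nM, and compound 3 gives 34600 nM; the result is a 1.3-fold higher number from compound 2 to compound 3 (0.10 log units; within the scatter). Compound 1 `COc1ccccc1Nc1nc(SCc2ccc(C(F)(F)F)cc2)nc2ccccc12` is compound 2 with methoxy in place of methyl on an aromatic carbon. In this assay compound 1 reaches only a limit, > 50000 nM, as the limit of > 50000 nM in this assay, at which 1 of the 3 values shown sits, records. That change made an at least 1.8-fold higher number from compound 2 to compound 1 (0.25 log units; that floor lies within the scatter). Compound 4 `COc1ccc(Nc2nc(SCc3ccc(C(F)(F)F)cc3)nc3ccccc23)cc1` is compound 3 with the same kind of change, (methoxy in place of methyl on an aromatic carbon); here the new group sits para to a large group, where earlier it sat ortho to a large group. Because an at least 1.8-fold higher number from compound 2 to compound 1 (0.25 log units; that floor lies within the scatter) pointed to a higher number, compound 4 is expected to follow with a step of a 1.4-fold higher number from compound 3 to compound 4 (0.16 log units; within the scatter). Compound 4 is therefore estimated at 50000 nM, between 20000 nM and 120000 nM, in this assay.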

Compound 4, half-maximal inhibitory concentration: 23500 nM
Beside the measured number, compound 4's estimate is 2.1-fold (0.33 log units) above it; the measured number falls inside the stated range.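

On the core of compound 3, methoxy in place of methyl gives a 1.5-fold lower number from compound 3 to compound 4 (0.17 log units; within the scatter), so in this assay this change has no clear effect there. Set beside the same change on the other core, it cannot be said either to carry over or to fail to carry over: the same change on two cores in this assay, an at least 1.8-fold higher number (0.25 log units; that floor lies within the scatter) from compound 2 to compound 1 and a 1.5-fold lower number (0.17 log units; within the scatter) from compound 3 to compound 4; the limit leaves it open whether they differ. Comparing across the two positions, 4-methoxyphenyl in place of 2-methoxyphenyl gives an at least 2.1-fold lower number from compound 1 to compound 4 (0.32 log units; beyond the scatter), the only new step beyond the scatter, while 4-methoxyphenyl in place of 2-methylphenyl gives a 1.2-fold lower number from compound 2 to compound 4 (0.07 log units; within the scatter).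

Compound 1 has only a limit, > 50000 nM, which leaves the true size of its steps open. Also open, from the compounds shown here alone, is how an amine or a carboxylic acid in place of the methoxy would read in this assay on either core.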